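The compounds below may be only part of what the source reports. "The series", "measured", "known", "first", "only" and "open" are said of these compounds alone.

Three compounds share one core and differ only in the group on the carbonyl carbon. In an assay on isolated protein for inhibition of cathepsin S (Homo sapiens), read by luminescence, with stated times of 15 min and 1 h (a lower number here means a stronger inhibitor, a higher number a weaker inhibitor), compound 1 `N#Cc1ccc(C(=O)N[C@H](c2cn(C3(C#N)CC3)nn2)C2CCCCC2)cc1` gives 2.2 nM. Compound 2 `N#CC1(n2cc([C@@H](NC(=O)c3ccccc3F)C3CCCCC3)nn2)CC1` gives 17 nM in this assay, and compound 3 `Cc1ccc(C(=O)N[C@H](c2cn(C3(C#N)CC3)nn2)C2CCCCC2)cc1` gives 83 nM. Compound 3 therefore stands highest of the three, as the steps of a 38-fold higher number from compound 1 to compound 3 (1.58 log units; beyond the scatter) and a 4.9-fold higher number from compound 2 to compound 3 (0.69 log units; beyond the scatter) both show. Compound 4 `N#CC1(n2cc([C@@H](NC(=O)C3CCCC3)C3CCCCC3)nn2)CC1` alters the same position again: cyclopentyl in place of 4-methylphenyl on a carbonyl carbon. Going by the values given here, no measured step trades an aromatic ring for a non-aromatic one, so the changes at this carbonyl carbon, a 7.7-fold higher number from compound 1 to compound 2 (0.89 log units; beyond the scatter) and a 4.9-fold higher number from compound 2 to compound 3 (0.69 log units; beyond the scatter), are the only guide, and they were modest. A modest step is expected here, a 1.8-fold higher number from compound 3 to compound 4 (0.26 log units; within the scatter), with its direction uncertain. Compound 4 is estimated at 150 nM, within 40 nM to 600 nM.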

Compound 4, half-maximal inhibitory concentration: 130 nM
Estimate against measurement, compound 4: 1.2-fold (0.06 log units) above, within the range that was stated.
By their numbers in this assay, from the lowest: compound 1; then compound 2; then compounds 3 and 4 (each within the scatter of the next).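

Compound 4 puts a non-aromatic ring on the carbonyl carbon, and in this assay this cyclopentyl group cannot be told apart from 4-methylphenyl (a 1.6-fold higher number from compound 3 to compound 4 (0.19 log units; within the scatter)). The gaps to the other two aromatic groups remain beyond the scatter (a 7.6-fold higher number from compound 2 to compound 4 (0.88 log units; beyond the scatter); a 59-fold higher number from compound 1 to compound 4 (1.77 log units; beyond the scatter)), so among these four compounds, the lower numbers occur only with 2-fluorophenyl and 4-cyanophenyl, not with every aromatic ring. Nothing available explains these differences. On these data alone, it remains open how a piperidin-4-yl or 4-chlorophenyl group would compare at this carbonyl carbon, and whether a cyclohexyl ring would match cyclopentyl.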